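Swapping the aromatic arm of compound 2 for furan

The compounds below may be only part of what the source reports. "The series", "measured", "known", "first", "only" and "open" are said of these compounds alone.

- compound 1 `COC1=C(C)C(=O)/C(=C(O)/C=C/c2ccc(F)cc2)C(=O)C1(C)C` gives 3.6 ug/mL
- compound 2 `COC1=C(C)C(=O)/C(=C(O)/C=C/c2ccc(C)cc2)C(=O)C1(C)C` gives 4.1 ug/mL
- compound 3 `COC1=C(C)C(=O)/C(=C(O)/C=C/c2c(C)cc(C)cc2C)C(=O)C1(C)C` gives 8.4 ug/mL

These numbers come from a functional assay on HCT-8 cells (Homo sapiens) for cytotoxicity (on this read-out lower numbers stand for an effect already at smaller amounts and higher numbers for an effect only at larger amounts of compound), and all three compounds share one core. Compound 2 lies at the low end of this short range together with compound 1, and compound 3 stands apart with a larger number.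

Compound 4 `COC1=C(C)C(=O)/C(=C(O)/C=C/c2ccco2)C(=O)C1(C)C` has not been measured yet. In it, furan-2-yl replaces 4-methylphenyl on a double-bonded chain carbon bound to a double-bonded chain carbon (furan-2-yl in place of 4-methylphenyl on a double-bonded chain carbon bound to a double-bonded chain carbon). Going by the values given here, no measured step exchanges a whole ring. The closest guide is a swap on the aromatic ring (a 1.1-fold higher number from compound 1 to compound 2 (0.06 log units; within the scatter)). Across the aromatic groups tested so far, the numbers span only the short range from compound 1 (3.6 ug/mL) to compound 3 (8.4 ug/mL). No step beyond the scatter is therefore expected in this assay, though a ring exchange leaves this uncertain. The estimated step is small (a 1.1-fold higher number from compound 2 to compound 4 (0.04 log units; within the scatter)). Compound 4 is estimated at 4.5 ug/mL (expected range 2 ug/mL to 10 ug/mL).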

Compound 4, concentration for half-maximal effect: 17.5 ug/mL
Beside the measured number, compound 4's estimate is 3.9-fold (0.59 log units) below it; measured number above the stated range.
By their numbers in this assay, from the lowest: compounds 1 and 2 (each within the scatter of the next); then compound 3; then compound 4.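

In this assay, this position proves sensitive to a change of the whole ring: furan-2-yl in place of 4-methylphenyl gives a 4.3-fold higher number from compound 2 to compound 4 (0.63 log units; beyond the scatter), and furan-2-yl in place of 4-fluorophenyl gives a 4.9-fold higher number from compound 1 to compound 4 (0.69 log units; beyond the scatter), so an effect now appears that the swap of a single ring substituent did not show. The exchange alters several things at once, as the six-membered ring of carbon only gives way to a five-membered aromatic ring with fewer heavy atoms, one hetero atom and a hydrogen-bond acceptor. Nothing available explains why the number rises.

The compounds shown leave open whether the ring size or the ring oxygen goes with the higher number. A thiophene ring or a pyridine ring on this chain carbon could help separate the two.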